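The compounds below may be only part of what the source reports. "The series", "measured", "known", "first", "only" and "open" are said of these compounds alone.

Measured compounds:
- compound 1 `CCN1C/C(=C\c2ccc(OC)c(OC)c2)C(=O)/C(=C/c2ccc(OC)c(OC)c2)C1` gives 3600 nM in a functional assay on NCI-H460 cells (Homo sapiens) for cytotoxicity, read by MTT assay, with a stated time of 72 h; on this read-out lower numbers stand for stronger inhibition and higher numbers for weaker inhibition
- compound 2 `COc1cc(/C=C2\CN(C)C/C(=C\c3cc(OC)c(OC)c(OC)c3)C2=O)cc(OC)c1OC` gives 1000 nM in this assay
- compound 3 `COc1cc(/C=C2\CN(C(=O)C(C)C)C/C(=C\c3cc(OC)c(OC)c(OC)c3)C2=O)cc(OC)c1OC` gives 2000 nM in this assay

Compound 1 holds the highest number of the three; its gap to compound 3 lies within the scatter, its gap to compound 2 beyond it. Compound 4 `COc1ccc(/C=C2\CNC/C(=C\c3ccc(OC)c(OC)c3)C2=O)cc1OC` differs from compound 1 by hydrogen in place of ethyl on an amine nitrogen in a ring. Among the measured compounds shown here, the only measured step touching the same position is a 2.0-fold higher number from compound 2 to compound 3 (0.30 log units; within the scatter), a small change within the scatter, on a different pair of aryl groups. For the measured compounds named here, no measured step removes the substituent from the ring nitrogen altogether, so the data give little guidance. Compound 4 is expected close to compound 1, with a 1.2-fold lower number from compound 1 to compound 4 (0.08 log units; within the scatter) as the estimated step, not beyond the scatter. The estimate for compound 4 is 3000 nM, ranging from 1200 nM to 9000 nM.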

Compound 4, half-maximal inhibitory concentration: 6400 nM
Compound 4: the middle estimate sits 2.1-fold (0.33 log units) below what was measured, within the range that was stated.
By their numbers in this assay, from the lowest: compounds 2, 3, 1 and 4 (each within the scatter of the next, the first and the last beyond it).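

In this assay, among the compounds shown here, hydrogen in place of ethyl on an amine nitrogen in a ring gives a 1.8-fold higher number from compound 1 to compound 4 (0.25 log units; within the scatter) as the first measured step that leaves this nitrogen without a substituent. Earlier, this position had shown only one substituent exchanged for another, on a different pair of aryl groups, whereas here ethyl and hydrogen are not told apart beyond the scatter. No measured evidence bears on this step.

Still open, on these data alone, is whether a longer chain or a carboxylic acid on this nitrogen would move the number beyond the scatter. Also open, as far as these compounds go, is whether hydrogen here would give a similar step with the aryl groups of compound 2.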